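Working notes: amine substituent step, compound 2 to compound 3

This account rests on a few compounds, and the source may have more. Where it says the series, first, only, none or still open, it means among the compounds named here.

Measured compounds:
compound 1 `CCCn1c(=O)[nH]c2nc(-c3ccc(S(=O)(=O)N4CCN(c5ccc(Cl)cc5F)CC4)cc3)[nH]c2c1=O` — > 1000 nM
compound 2 `CCCn1c(=O)[nH]c2nc(-c3ccc(S(=O)(=O)N4CCN(Cc5cccc(Br)c5)CC4)cc3)[nH]c2c1=O` — 928 nM

In an assay on CHO cells for displacement of a labelled ligand from adenosine receptor A1 (Homo sapiens), read by scintillation counting, with a stated time of 90 min, in the presence of a further agent that is not named here (a higher number here means a weaker inhibitor, a lower number a stronger inhibitor), compound 2 gives 928 nM. In this assay compound 1 gives > 1000 nM, which is a limit of the assay and not a number; it sits at the limit of > 1000 nM in this assay, at which 1 of the 2 values shown sits. Compound 2 therefore holds the only number shown in the set. Within the data shown here, the single measured step, an at least 1.0-fold lower number from compound 1 to compound 2 (0.03 log units; that floor lies within the scatter), is a floor that lies within the scatter, so it gives no direction.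

Compound 3 `CCCn1c(=O)[nH]c2nc(-c3ccc(S(=O)(=O)N4CCN(C(C)c5ccccc5)CC4)cc3)[nH]c2c1=O` differs from compound 2 by 1-phenylethyl in place of 3-bromobenzyl on an amine nitrogen in a ring. Among the measured compounds shown here, no measured step exchanges one group of this kind for another on that ring nitrogen; the one step available compares an aryl group with a benzyl group and is itself bounded by a limit. Nothing in the data therefore supports a step beyond the scatter in this assay, in either direction, and a limit rather than a number remains a real possibility.

Compound 3 is expected to give 1000 nM in this assay, within 300 nM to 3500 nM. The estimated step is a 1.1-fold higher number from compound 2 to compound 3 (0.03 log units; within the scatter).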

Compound 3, inhibition constant: >= 1000 nM
Compound 3 ended at the assay's limit; the forecaster's own chance of this, stated with the estimate: 45%; the middle value lies on the limit itself.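

In this assay compound 3 gives >= 1000 nM, which is a limit of the assay and not a number: the limit of >= 1000 nM in this assay, at which 1 of the 3 values shown sits.

On the amine nitrogen in a ring, 1-phenylethyl in place of 3-bromobenzyl gives an at least 1.0-fold higher number from compound 2 to compound 3 (0.03 log units; that floor lies within the scatter), a floor that sets no direction, so this exchange between two groups of 8 heavy atoms, each with one six-membered aromatic ring of carbon only, produces no readable step in this series. Among these compounds, it is also the first exchange at this position between two such groups, yet compound 2 remains the only compound of the three with a number, and the step from compound 1 to compound 3 cannot be read.

On these data alone, it remains open whether a 2-phenylethyl group, with its longer chain, or a benzyl group carrying an amine or a carboxylic acid on this ring nitrogen would give a number beyond the scatter from that of compound 2. Also open, as far as these compounds go, is what the bromine contributes on its own, which a plain benzyl group on the same nitrogen would separate from the effect of the added methyl branch.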